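Adding a methoxy group to compound 2

The source may hold more compounds than are shown below. What is called first, only, known or untested is meant among the compounds shown, and "the series" means these compounds.

In a functional assay on SK-MEL cells (Homo sapiens) for cytotoxicity, read by MTT assay, with a stated time of 6 days (on this read-out lower numbers stand for an effect already at smaller amounts and higher numbers for an effect only at larger amounts of compound), compound 1 `COC(=O)c1c(-c2ccc(OCc3ccccc3)cc2)oc2ccc(OC)cc2c1=O` gives 20.9 ug/mL. Compound 2 `COC(=O)c1c(-c2ccc(O)cc2)oc2ccccc2c1=O` gives > 25 ug/mL, which is a limit of the assay and not a number. On these data alone, compound 2 therefore stands at the limit of > 25 ug/mL in this assay, at which 1 of the 2 values shown sits, and its true position remains unknown. Compound 3 `COC(=O)c1c(-c2ccc(O)cc2)oc2ccc(OC)cc2c1=O` differs from compound 2 by a single change, (methoxy in place of hydrogen on an aromatic carbon). Going by the values given here, no measured step in this assay shows what this change does, so only a modest shift towards smaller amounts is expected, possibly none beyond the scatter. Among the compounds with values here, the one numerical reading so far, compound 1 at 20.9 ug/mL, suggests that a number of similar size is a reasonable expectation. The expected move is an at least 1.0-fold lower number from compound 2 to compound 3 (0.03 log units; that floor lies within the scatter). Compound 3 is estimated at 23 ug/mL, with an expected range from 13 ug/mL to 45 ug/mL.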

Compound 3, concentration for half-maximal effect: 18.7 ug/mL
Beside the measured number, compound 3's estimate is 1.2-fold (0.09 log units) above it, and the stated range covers the measured number.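

For methoxy in place of hydrogen on an aromatic carbon, this assay now gives a first reading: an at least 1.3-fold lower number from compound 2 to compound 3 (0.12 log units; that floor lies within the scatter). On these data alone, how large this step really is stays unknown at its upper end, since compound 2 is only a limit and not a number: the limit of > 25 ug/mL in this assay, at which 1 of the 3 values shown sits. The reading for hydrogen in place of benzyl on the oxygen on the aromatic ring is a 1.1-fold lower number from compound 1 to compound 3 (0.05 log units; within the scatter), so compound 1 and compound 3 cannot be put in any order, and with methoxy present this exchange shows no readable step.

Open remains how far compound 2 truly lies from compound 3. Also open, as far as these compounds go, is how an amine or a longer chain such as butoxy in place of methoxy on that aromatic carbon would read.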